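From phenoxy to trifluoromethoxy on the shared core

The compounds below may be only part of what the source reports. "The series", "measured", "known", "first", "only" and "open" are said of these compounds alone.

Compound 1 `CCOC(=O)c1c(-c2cccc(OC)c2)[nH]c2cc(OC)c(F)cc2c1=O`, compound 2 `CCOC(=O)c1c(-c2cccc(Oc3ccccc3)c2)[nH]c2cc(OC)c(F)cc2c1=O` and compound 3 `CCOC(=O)c1c(-c2cccc(OC(F)(F)F)c2)[nH]c2cc(OC)c(F)cc2c1=O` share one core. In an ADME assay on BJ cells (Homo sapiens) for cytotoxicity, read by luminescence, with a stated time of 72 h (a lower number here means that less compound is needed, a higher number that more compound is needed for the effect), compound 1 gives > 21500 nM, a limit of the assay and not a number. Compound 2 gives > 21500 nM, again only a limit, so compound 2 has no readable position in the series.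

Going to compound 3 puts trifluoromethyl in place of phenyl on an oxygen on an aromatic ring. Among the measured compounds shown here, one measured step bears on this oxygen, a step that the two limits leave unreadable from compound 1 to compound 2, and it has no readable size. Both measured compounds sit at the limit of > 21500 nM in this assay, at which 2 of the 2 values shown sit. No measured number therefore points to a change in either direction.

The expected step in this assay is a number no higher from compound 2 to compound 3 (the limit leaves the size open), with none beyond the scatter expected. Compound 3 is estimated at 21500 nM, with an expected range of 12000 nM to 40000 nM.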

Compound 3, half-maximal effective concentration: > 21500 nM
Compound 3 was reported as a limit (the forecaster's own chance of this, stated with the estimate: 85%); the middle value lies on the limit itself.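

In this assay compound 3 gives > 21500 nM, a limit of the assay and not a number. No step among compound 1, compound 2 and compound 3 can be read: the limit of > 21500 nM in this assay, at which 3 of the 3 values shown sit.

From the compounds shown here alone, whether the group on this oxygen alters the concentration needed for the effect in this assay remains open.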